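Dropping the methyl from compound 3

The source may hold more compounds than are shown below. What is called first, only, known or untested is meant among the compounds shown, and "the series" means these compounds.

In a functional assay on HepG2 cells (Homo sapiens) for inhibition, read by MTT assay, with a stated time of 24 h, tested at 10 uM (on this read-out lower numbers stand for less inhibition of growth and higher numbers for more inhibition of growth at the one concentration tested), compound 3 `Cc1ccc(-c2nnc(-c3c[nH]c4ncc(-c5ccc(S(C)(=O)=O)cc5)cc4c3=O)o2)cc1` gives 8.94%, the lowest of three numbers, though all three lie within the scatter of one another. Compound 2 `CS(=O)(=O)c1ccc(-c2cnc3[nH]cc(-c4nnc(-c5ccc(F)cc5)o4)c(=O)c3c2)cc1` gives 11.1% and compound 1 `N#Cc1ccc(-c2cnc3[nH]cc(-c4nnc(-c5ccc(Cl)cc5)o4)c(=O)c3c2)cc1` gives 12.7%. Compound 4 `CS(=O)(=O)c1ccc(-c2cnc3[nH]cc(-c4nnc(-c5ccccc5)o4)c(=O)c3c2)cc1` differs from compound 3 by hydrogen in place of methyl on an aromatic carbon. Among the compounds with values here, only one measured step bears on this change, a number 2.2 percentage points lower from compound 2 to compound 3 (within the scatter), which altered the group on the same aromatic carbon and stayed within the scatter. Since every measured compound sits in a narrow band of low inhibition, no step beyond the scatter is expected here. Compound 4 is therefore estimated at 10%, with a range of 3% to 18%. This estimate implies an expected step of a number 1.1 percentage points higher from compound 3 to compound 4 (within the scatter).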

Compound 4, percent growth inhibition at one concentration: 6.98%
Estimate against measurement, compound 4: 3 percentage points above; low and high end bracket the measured number.
By their numbers in this assay, from the lowest: compounds 4, 3, 2 and 1 (each within the scatter of the next).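

In this assay the loss of the methyl gives a number 2 percentage points lower from compound 3 to compound 4 (within the scatter) and hydrogen in place of fluoro gives a number 4.1 percentage points lower from compound 2 to compound 4 (within the scatter) on the same carbon. On this aromatic carbon, para to a large group, hydrogen, methyl and fluoro therefore cannot be told apart on this read-out, and the bare phenyl shows that neither substituent is needed for the low inhibition seen. Nothing available accounts for this flatness.

From the compounds shown here alone, whether an amine or a carboxylic acid on this carbon would move the number beyond the scatter remains open.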